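Swapping fluoro for bromo on the methylated analogue

A few compounds are considered here, and "the series" means these few. Any claim that something is new, unique, unknown or untested is made for them only; others in the source may bear on it.

Of the compounds shown here, three sharing one core have been tested in a functional assay on HT-29 cells (Homo sapiens) for antiproliferative activity, read by MTT assay, with a stated time of 72 h; on this read-out higher numbers stand for weaker inhibition and lower numbers for stronger inhibition. Compound 1 `O=C(Nc1ccc(Oc2ccnc3[nH]ccc23)cc1)c1cc2cccnc2n(-c2ccc(F)cc2)c1=O` gives 160 nM. Compound 2 `O=C(Nc1ccc(Oc2ccnc3[nH]ccc23)cc1)c1cc2cccnc2n(-c2ccc(Br)cc2)c1=O` gives 270 nM. Compound 3 `Cn1ccc2c(Oc3ccc(NC(=O)c4cc5cccnc5n(-c5ccc(F)cc5)c4=O)cc3)ccnc21` gives 250 nM, the second highest of the three numbers, though its gaps to compound 2 and to compound 1 both lie within the scatter, so no order among them can be claimed. Compound 4 `Cn1ccc2c(Oc3ccc(NC(=O)c4cc5cccnc5n(-c5ccc(Br)cc5)c4=O)cc3)ccnc21` has not been measured; it differs from compound 3 by bromo in place of fluoro on an aromatic carbon. One measured step shows this very change on the otherwise unmethylated pair: a 1.7-fold higher number from compound 1 to compound 2 (0.23 log units; within the scatter). The other measured step, a 1.6-fold higher number from compound 1 to compound 3 (0.19 log units; within the scatter), also stays within the scatter. With only these two steps to go on, a shift of about the same size as the first, toward a higher number, is expected in this assay, and it may well remain within the scatter. Compound 4 is therefore expected to give 420 nM, with a likely range from 200 nM to 900 nM. That estimate means a 1.7-fold higher number from compound 3 to compound 4 (0.23 log units; within the scatter).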

Compound 4, half-maximal inhibitory concentration: 690 nM
For compound 4 the middle estimate is 1.6-fold (0.22 log units) below the measured one; the measured number falls inside the stated range.
By their numbers in this assay, from the lowest: compounds 1, 3 and 2 (each within the scatter of the next); then compound 4.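

In this assay, the change from 4-fluorophenyl to 4-bromophenyl now gives a step beyond the scatter on the methylated core, a 2.8-fold higher number from compound 3 to compound 4 (0.44 log units; beyond the scatter), whereas on the unmethylated pair it stayed within the scatter. Even so, the two readings of this change cannot be told apart, so the core need not alter what the swap does: the same change on two cores in this assay, a 1.7-fold higher number (0.23 log units; within the scatter) from compound 1 to compound 2 and a 2.8-fold higher number (0.44 log units; beyond the scatter) from compound 3 to compound 4, 1.6-fold (0.21 log units) apart, within the scatter of two such steps

Adding methyl on the aromatic nitrogen also now gives a step beyond the scatter when bromo is present, a 2.6-fold higher number from compound 2 to compound 4 (0.41 log units; beyond the scatter), and again the two readings cannot be told apart: the same change on two cores in this assay, a 1.6-fold higher number (0.19 log units; within the scatter) from compound 1 to compound 3 and a 2.6-fold higher number (0.41 log units; beyond the scatter) from compound 2 to compound 4, 1.6-fold (0.21 log units) apart, within the scatter of two such steps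

The compounds shown leave open whether chloro or methoxy at this place would read closer to fluoro or to bromo. They also leave open what an ethyl group or a longer chain on that nitrogen would do to the number.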